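The compounds below may be only part of what the source reports. "The series", "measured", "known", "first", "only" and "open" are said of these compounds alone.

Two compounds with a shared core carrying an eight-carbon chain have been measured for how much of them survives a liver preparation. Compound 1 `CCCCCCCCc1ccc(OCC(=O)Cn2nnc(-c3cccc(S(=O)(=O)N(C)C)c3)n2)cc1` gives 9% in an ADME assay on S9 fraction from liver (Rattus norvegicus) for metabolic stability, read by LC-MS, using NADPH, with a stated time of 30 min; a lower number here means that less of the compound is left, a higher number that more of the compound is left. Compound 2 `CCCCCCCCc1ccc(OCC(=O)Cn2nnnc2SC)cc1` gives 21% in this assay, which is the higher of the two numbers; the gap to compound 1 lies beyond the scatter of this kind of measurement, so compound 2 stands as the more stable of the pair in this assay.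

Compound 3 `CCCCCCCCc1ccc(OCC(=O)Cn2nnnc2C(=O)OC)cc1` has not yet been measured. It differs from compound 2 in one place: methoxycarbonyl in place of methylsulfanyl on an aromatic carbon. The change sits on an aromatic carbon of the five-membered ring with four nitrogen atoms, between two ring nitrogen atoms.

Among the compounds with values here, with only two measured compounds and no step between them that matches this change, there is little to anchor an expectation. Compound 3 is expected to come out lower than compound 2, giving a step of a number 9 percentage points lower from compound 2 to compound 3 (within the scatter) in this assay, though the direction is uncertain. The estimate for compound 3 is 12%, with a range from 3% to 30%.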

Compound 3, percent of the compound remaining: 38%
The estimate for compound 3 lay 26 percentage points below the measured number; measured number outside the range, above it.
By their numbers in this assay, from the lowest: compound 1; then compound 2; then compound 3.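

In this assay, putting methoxycarbonyl in place of methylsulfanyl on the aromatic carbon between two ring nitrogen atoms gives a number 17 percentage points higher from compound 2 to compound 3 (beyond the scatter). Within the data shown here, this is the first step in the set that changes only this position, and it shows that the group held here can alter how much compound is left after the incubation, even though the rest of the molecule stays the same. Nothing measured here explains the rise, so the step stands as an observation from a single pair of compounds, with no cause attached to it.

Two groups at one position cannot show whether the number would keep rising with other groups there, such as an ethyl ester, a primary amide, a carboxylic acid or a simple amine, so no trend can yet be drawn. As far as these compounds go, it also remains open whether the same swap would give a similar step if the shared eight-carbon chain were replaced by a shorter chain, or whether that chain has any bearing on the numbers at all.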